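The source may hold more compounds than are shown below. What is called first, only, known or untested is meant among the compounds shown, and "the series" means these compounds.

Measured so far:
compound 1 `COc1cc(/C=C/C(=O)/C=C/c2ccccc2)ccc1OCc1cn(CCCOc2cc(=O)oc3ccccc23)nn1`: 45%
compound 2 `COc1ccc(/C=C/C(=O)/C=C/c2ccc(OCc3cn(CCCCCOc4cc(=O)oc5ccccc45)nn3)c(OC)c2)cc1`: 35%
compound 3 `COc1cc(/C=C/C(=O)/C=C/c2ccccc2)ccc1OCc1cn(CCCCCOc2cc(=O)oc3ccccc23)nn1`: 24%

In a functional assay on HCT-116 cells (Homo sapiens) for inhibition, read by sulforhodamine B assay, with a stated time of 48 h, tested at 50 uM (a lower number here means less inhibition of growth, a higher number more inhibition of growth at the concentration tested), compound 1 gives the highest of the three numbers. Compound 2 stands nearest, a number that lies within the scatter of compound 1, so no order between compound 1 and compound 2 can be read. Compound 3 stands furthest, beyond the scatter. Among the compounds with values here, the one step measured, a number 11 percentage points lower from compound 2 to compound 3 (beyond the scatter), concerns hydrogen in place of methoxy on an aromatic carbon and touches no part of the structure changed here.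

Compound 4 `COc1cc(/C=C/C(=O)/C=C/c2cccc3ccccc23)ccc1OCc1cn(CCCOc2cc(=O)oc3ccccc23)nn1` differs from compound 1 in one place: naphthalen-1-yl in place of phenyl on a double-bonded chain carbon bound to a double-bonded chain carbon

Within the data shown here, no measured step bears on this change; nothing exchanges one aromatic ring system for another on the chain. The expectation therefore rests on compound 1 alone, with 45% as the anchor, and no step beyond the scatter is expected in either direction in this assay. Compound 4 is estimated at 45%, in the range 25% to 65%, which means an expected step of no change at the digits printed from compound 1 to compound 4 (within the scatter).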

Compound 4, percent growth inhibition at one concentration: 66%
Compound 4: middle estimate off by 21 percentage points, on the low side; measured number above the stated range.
By their numbers in this assay, from the lowest: compound 3; then compounds 2 and 1 (each within the scatter of the next); then compound 4.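

In this assay, naphthalen-1-yl in place of phenyl on a double-bonded chain carbon bound to a double-bonded chain carbon gives a number 21 percentage points higher from compound 1 to compound 4 (beyond the scatter), so this end of the molecule responds to an exchange of the ring system itself. Within the data shown here, the only earlier step at this aryl group, a number 11 percentage points lower from compound 2 to compound 3 (beyond the scatter), changed a substituent on the phenyl ring and left the ring in place, so it could not show this. Nothing at hand accounts for the size of the new step.

As far as these compounds go, the step rests on one pair, on the chain of compound 1, and whether it carries over to the chain of compound 3 stays open. Also open, from the compounds shown here alone, is whether naphthalen-2-yl or a pyridine ring at the same place would give a similar number.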